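This account rests on a few compounds, and the source may have more. Where it says the series, first, only, none or still open, it means among the compounds named here.

In a physicochemical assay for solubility, at pH 7.4 (a lower number here means a less soluble compound, a higher number a more soluble compound), compound 1 `Cc1cc(NC(=O)Nc2ccccc2C(C)(C)C)c2ccccc2n1` gives 100 nM as the lowest of three numbers, with compound 2 `Cc1cc(NC(=O)Nc2ccc(OC(F)(F)F)cc2)c2ccccc2n1` at 300 nM and compound 3 `COc1ccc(NC(=O)Nc2cc(C)nc3ccccc23)cc1` at 19800 nM as the highest. Compound 4 `Cc1cc(NC(=O)Nc2ccccc2[N+](=O)[O-])c2ccccc2n1` differs from compound 1 in one place, and that change is nitro in place of tert-butyl on an aromatic carbon. Among the compounds with values here, no measured step swaps either of these two groups. Within the data shown here, the one measured step that comes near is a 66-fold higher number from compound 2 to compound 3 (1.82 log units; beyond the scatter) for methyl in place of trifluoromethyl on an oxygen on an aromatic ring, and it lies elsewhere on the molecule. It bears only indirectly, showing that one small swap among these compounds can move the number a long way. With that large step in mind, and with compound 1 starting at 100 nM at the bottom of the measured numbers, a rise seems the likelier direction. The expected move is a 10-fold higher number from compound 1 to compound 4 (1.00 log units; beyond the scatter) in this assay upward and beyond the scatter, though with little certainty about its size. For compound 4 the estimated value is 1000 nM with 200 nM to 5000 nM as the expected range.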

Compound 4, solubility: 200 nM
Compound 4: the middle estimate sits 5.0-fold (0.70 log units) above what was measured; the range from low to high includes it.
By their numbers in this assay, from the lowest: compounds 1, 4 and 2 (each within the scatter of the next, the first and the last beyond it); then compound 3.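

In this assay, replacing tert-butyl with nitro on this aromatic carbon, ortho to a large group, gives a 2.0-fold higher number from compound 1 to compound 4 (0.30 log units; within the scatter), so the measurement does not separate the two compounds. Tert-butyl contains only carbon, while nitro brings in nitrogen, oxygen and hydrogen-bond acceptors, yet this clear difference in atoms produces no step beyond the scatter, unlike a 66-fold higher number from compound 2 to compound 3 (1.82 log units; beyond the scatter), which comes from a swap elsewhere on the molecule. Nothing available here bears on the reason for this result.

On these data alone, whether an amine or a carboxylic acid on this same aromatic carbon would also stay within the scatter of compound 1 remains open. Also open is how far this one result can be generalized, since it is the only step shown at this position.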